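This account rests on a few compounds, and the source may have more. Where it says the series, first, only, none or still open, it means among the compounds named here.

Compound 1 `CC[C@H]1OC(=O)[C@H](C)[C@@H](O[C@H]2C[C@@](C)(OC)[C@@H](OCCCNC(=O)COC)[C@H](C)O2)[C@H](C)[C@@H](O[C@@H]2O[C@H](C)C[C@H](N(C)C)[C@H]2O)[C@](C)(O)C[C@@H](C)CN(C)[C@H](C)[C@@H](O)[C@]1(C)O` gives 2.16 in a physicochemical assay for lipophilicity, read by HPLC, measured as chromatographic lipophilicity, at pH 7.4; a lower number here means a more polar compound, a higher number a more lipophilic compound.
Compound 2 `CC[C@H]1OC(=O)[C@H](C)[C@@H](O[C@H]2C[C@@](C)(OC)[C@@H](O)[C@H](C)O2)[C@H](C)[C@@H](O[C@@H]2O[C@H](C)C[C@H](N(C)C)[C@H]2OCCCNC(=O)C2CCC2)[C@](C)(O)C[C@@H](C)CN(C)[C@H](C)[C@@H](O)[C@]1(C)O` gives 3.16 in this assay.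
Compound 3 `CC[C@H]1OC(=O)[C@H](C)[C@@H](OCCCNC(=O)C2CCC2)[C@H](C)[C@@H](O[C@@H]2O[C@H](C)C[C@H](N(C)C)[C@H]2O)[C@](C)(O)C[C@@H](C)CN(C)[C@H](C)[C@@H](O)[C@]1(C)O` gives 1.78 in this assay.

Among these three, compound 1 stands second highest in this assay. Its nearest neighbour is compound 3, whose value lies lower by an amount beyond the scatter of the assay; the furthest is compound 2, whose value lies higher, again by more than the scatter. Within the data shown here, all three share the same macrocyclic core and differ in how the side chain is attached and what it carries, but no pair among them differs in only one place, so no single measured step can be taken directly from them.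

The unmeasured compound 4 `CC[C@H]1OC(=O)[C@H](C)[C@@H](O[C@H]2C[C@@](C)(OC)[C@@H](OCCCNC(=O)c3c(C)nn(C)c3Cl)[C@H](C)O2)[C@H](C)[C@@H](O[C@@H]2O[C@H](C)C[C@H](N(C)C)[C@H]2O)[C@](C)(O)C[C@@H](C)CN(C)[C@H](C)[C@@H](O)[C@]1(C)O` comes from compound 1 by one change (5-chloro-1,3-dimethyl-1H-pyrazol-4-yl in place of methoxymethyl on a carbonyl carbon). Among the measured compounds shown here, no measured pair shows this replacement, so the expectation rests on the change itself rather than on a measured step. The step from compound 1 to compound 4 in this assay is expected to be upward and clearly beyond the scatter, at about a number 1.04 log units higher from compound 1 to compound 4 (beyond the scatter). On that basis, compound 4 is expected to give roughly 3.2 in this assay, with a plausible range from 2.6 to 3.8.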

Compound 4, distribution coefficient: 2.52
Beside the measured number, compound 4's estimate is 0.68 log units above it, and the stated range ends above it.
By their numbers in this assay, from the lowest: compound 3; then compound 1; then compound 4; then compound 2.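

In this assay, among these compounds, the exchange of methoxymethyl for 5-chloro-1,3-dimethyl-1H-pyrazol-4-yl, on a carbonyl carbon whose other neighbour is an amide-type nitrogen, gives a number 0.36 log units higher from compound 1 to compound 4 (beyond the scatter) and is the first change in the set that can be read on its own. The earlier compounds shown here differed in more than one place, so they could not separate the group on this carbonyl carbon from the rest of the side chain and its attachment; this pair shows that the group at this place alone moves the number, by a modest step that still lies beyond the scatter. Nothing available accounts for the size or direction of this step.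

With a single replacement at this place, the compounds shown do not tell how much of the step belongs to the chlorine, the two methyl groups or the aromatic ring itself, which a 1,3-dimethyl-1H-pyrazol-4-yl group without chlorine or a plain phenyl group could begin to separate. Going by these compounds, it also remains open how a carboxylic acid or an amine on this carbonyl carbon would read, and whether the same exchange gives a similar step when the chain sits elsewhere on the shared core.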